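A few compounds are considered here, and "the series" means these few. Any claim that something is new, unique, unknown or untested is made for them only; others in the source may bear on it.

In an ADME assay on L1210/0 cells (Mus musculus) for cytotoxicity, with a stated time of 48 h (a lower number here means a stronger inhibitor, a higher number a weaker inhibitor), compound 1 (`O=c1[nH]c(=O)n([C@H]2C[C@H](O)[C@@H](CO)O2)cc1/C=C/I`) gives 63900 nM. Compound 2 (`CCC#Cc1cn([C@H]2C[C@H](O)[C@@H](CO)O2)c(=O)[nH]c1=O`) gives > 200000 nM, which is a limit of the assay and not a number. Within the data shown here, the only measured step is an at least 3.1-fold higher number from compound 1 to compound 2 (0.49 log units; beyond the scatter), and it concerns a different structural change. Compound 3 (`CCCCC#Cc1cn([C@H]2C[C@H](O)[C@@H](CO)O2)c(=O)[nH]c1=O`) differs from compound 2 by ethyl in place of hydrogen on a saturated chain carbon, two bonds along the chain from a triple-bonded carbon, which reads as but-1-yn-1-yl to hex-1-yn-1-yl. No step beyond the scatter is expected in this assay, and a further limit is the likeliest result. The expected change is a number no higher from compound 2 to compound 3 (the limit leaves the size open). For compound 3 the estimated value is 200000 nM, with an expected range of 90000 nM to 400000 nM.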

Compound 3, half-maximal inhibitory concentration: > 200000 nM
Compound 3: only a limit was reported; the forecaster's own chance of this, stated with the estimate: 65%; the middle value lies on the limit itself.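

In this assay, the exchange of one group gives an at least 3.1-fold higher number from compound 1 to compound 3 (0.49 log units; beyond the scatter), so this second alkynyl chain also stands on the weaker side of compound 1. The value of compound 3 is a limit and not a number, so the change from but-1-yn-1-yl to hex-1-yn-1-yl cannot be read: the limit of > 200000 nM in this assay, at which 2 of the 3 values shown sit. Adding ethyl to the chain therefore brings no readable number. As far as these compounds go, whether a longer chain, or an amine or carboxylic acid in place of the ethyl, would give a value under the limit stays open. From the compounds shown here alone, how far compound 2 and compound 3 lie beyond it also stays open.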